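Returning a Furan to the Shared Core

The source may hold more compounds than are shown below. What is called first, only, known or untested is meant among the compounds shown, and "the series" means these compounds.

Compound 2 `O=c1[nH]cnc2c1c(-c1ccsc1)cn2[C@@H]1O[C@H](CO)[C@@H](O)[C@H]1O` carries a thiophen-3-yl group on the shared core. In a functional assay on HCT-116 cells (Homo sapiens), read by MTT assay, with a stated time of 72 h (on this read-out lower numbers stand for stronger inhibition and higher numbers for weaker inhibition), compound 2 gives only a limit of the assay, > 20000 nM, and it sits at the limit of > 20000 nM in this assay, at which 1 of the 2 values shown sits. Compound 1 `O=c1[nH]cnc2c1c(-c1ccoc1)cn2[C@@H]1O[C@H](CO)[C@@H](O)[C@H]1O`, which bears furan-3-yl instead, gives 10300 nM in this assay. Among the compounds with values here, the single measured step, an at least 1.9-fold higher number from compound 1 to compound 2 (0.28 log units; that floor lies within the scatter), is the only guide available. Compound 3 `O=c1[nH]cnc2c1c(-c1ccco1)cn2[C@@H]1O[C@H](CO)[C@@H](O)[C@H]1O` differs from compound 2 by furan-2-yl in place of thiophen-3-yl on an aromatic carbon. Because compound 1 with its furan gives 10300 nM, compound 3 is expected near 15000 nM (range 5000 nM to 40000 nM), which means an expected step of an at least 1.3-fold lower number from compound 2 to compound 3 (0.12 log units; that floor lies within the scatter).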

Compound 3, half-maximal inhibitory concentration: 18300 nM
Estimate against measurement, compound 3: 1.2-fold (0.09 log units) below; low and high end bracket the measured number.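

The two furans cannot be told apart at this position in this assay: changing the point of attachment from furan-3-yl to furan-2-yl gives a 1.8-fold higher number from compound 1 to compound 3 (0.25 log units; within the scatter). The change from thiophen-3-yl to furan-2-yl gives an at least 1.0-fold lower number from compound 2 to compound 3 (0.03 log units; that floor lies within the scatter), so it separates these two groups no better. Compound 2 remains a limit of the assay and not a number: the limit of > 20000 nM in this assay, at which 1 of the 3 values shown sits.

All three groups shown are five-membered aromatic rings with 1 hetero atom. As far as these compounds go, whether an amine, a phenyl ring or a longer chain at this position would give a clearly lower number in this assay remains open.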